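Ethoxy to Isopropoxy on a Shared Core

The source may hold more compounds than are shown below. What is called first, only, known or untested is meant among the compounds shown, and "the series" means these compounds.

Of the compounds shown here, three built on one core have been measured in a functional assay on cells (T-cell, Homo sapiens) for inhibition; a higher number here means a weaker inhibitor, a lower number a stronger inhibitor. Compound 1 `COc1ccc(-c2cnc3nc(N)nc(N4CCN(C(=O)COc5ccccc5)CC4)c3n2)cc1OC` gives 4 nM. Compound 2 `COc1ccc(-c2cnc3nc(N)nc(N4CCN(C(=O)c5ccccc5)CC4)c3n2)cc1OC` gives 400 nM. In this assay the step between these two is a 100-fold higher number from compound 1 to compound 2 (2.00 log units; beyond the scatter). Compound 3 `CCOc1nc(N)nc2ncc(-c3ccc(OC)cc3)nc12` differs more widely from the first two, and for it the assay reports only a limit: compound 3 gives > 10000 nM. That limit is the limit of > 10000 nM in this assay, at which 1 of the 3 values shown sits, so compound 3 has no number of its own and stands apart from the two compounds that do.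

Compound 4 `COc1ccc(-c2cnc3nc(N)nc(OC(C)C)c3n2)cc1` differs from compound 3 in one place: methyl in place of hydrogen on a saturated chain carbon bound to an oxygen on an aromatic ring and a saturated chain carbon. Within the data shown here, the only measured step concerns the group on the carbonyl carbon and does not touch the alkoxy chain, so no measured step bears directly on this change. An addition of a single methyl of this kind gives no ground to expect a step beyond the scatter in this assay in either direction. Compound 4 is therefore expected to give about 20000 nM, in the range 5000 nM to 100000 nM. The step from compound 3 to compound 4 is estimated as a step that the limit leaves unreadable from compound 3 to compound 4, with a limit rather than a number the likelier report.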

Compound 4, half-maximal inhibitory concentration: > 10000 nM
Compound 4: only a limit was reported (the forecaster's own chance of this, stated with the estimate: 85%); the middle value lies beyond the limit too.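

In this assay compound 4 gives > 10000 nM, which is a limit and not a number. Compound 3 also has only a limit, so no step can be read between compound 3 and compound 4: the limit of > 10000 nM in this assay, at which 2 of the 4 values shown sit.

Going by these compounds, how isopropoxy compares with ethoxy in this assay stays open, as neither compound has a number of its own.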